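Benzyl ring substituent survey, compound 3 to compound 4

The source may hold more compounds than are shown below. What is called first, only, known or untested is meant among the compounds shown, and "the series" means these compounds.

Compound 3 `O=c1ccoc2cc(OCc3cn(Cc4ccc(Br)cc4)nn3)ccc12` gives 96400 nM in a functional assay on QGY7701 cells (Homo sapiens) for cytotoxicity, read by MTT assay, with a stated time of 48 h; on this read-out higher numbers stand for weaker inhibition and lower numbers for stronger inhibition. Compound 2 `Cc1ccc(Cn2cc(COc3ccc4c(=O)ccoc4c3)nn2)cc1` gives 68500 nM in this assay; compound 3 holds the highest of the two numbers, though the step of a 1.4-fold higher number from compound 2 to compound 3 (0.15 log units; within the scatter) sits within the scatter. Compound 1 `O=c1ccoc2cc(OCc3cn(Cc4ccccc4)nn3)ccc12` gives only a limit, > 100000 nM, in this assay. That value sits at the limit of > 100000 nM in this assay, at which 1 of the 3 values shown sits.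

The step to compound 4 `CC(C)(C)c1ccc(Cn2cc(COc3ccc4c(=O)ccoc4c3)nn2)cc1` is tert-butyl in place of bromo on an aromatic carbon. Bearing on it are an at least 1.0-fold lower number from compound 1 to compound 3 (0.01 log units; that floor lies within the scatter) and a 1.4-fold higher number from compound 2 to compound 3 (0.15 log units; within the scatter), both within the scatter, and so is an at least 1.4-fold lower number from compound 1 to compound 2 (0.16 log units; that floor lies within the scatter). Within this set each change on the benzyl aromatic carbon, hydrogen to methyl, hydrogen to bromo, methyl to bromo, has left the number where it was, give or take the scatter. No measured case of a tert-butyl group on that carbon exists here, so the step can only be read from those three. The expected step is therefore a 1.2-fold lower number from compound 3 to compound 4 (0.08 log units; within the scatter), none beyond the scatter. Compound 4 is estimated at 80000 nM in this assay, with a range from 35000 nM to 200000 nM, and a real chance that this assay again reports only a limit rather than a number.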

Compound 4, half-maximal inhibitory concentration: > 100000 nM
Compound 4 was reported as a limit; the forecaster's own chance of this, stated with the estimate: 35%; middle value at least 1.2-fold (0.09 log units) from the limit.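

In this assay compound 4 gives only a limit, the second such result in this small set: the limit of > 100000 nM in this assay, at which 2 of the 4 values shown sit. Within the data shown here, the steps of an at least 1.0-fold higher number from compound 3 to compound 4 (0.01 log units; that floor lies within the scatter) and an at least 1.4-fold higher number from compound 2 to compound 4 (0.16 log units; that floor lies within the scatter) are floors that lie within the scatter, so they fix no size, but they extend the earlier picture to a much bigger substituent: tert-butyl, with 4 heavy atoms where bromo has 1, also opens no step towards stronger inhibition on this aromatic carbon, para to a large group. The step between the other two compounds that pairs tert-butyl with hydrogen cannot be read, as both ends are limits, so nothing separates those two compounds.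

How far the two limit compounds lie from the measured ones stays open, and with it whether tert-butyl truly costs anything relative to methyl or bromo, since no step in this set is shown beyond the scatter. Equally open, from the compounds shown here alone, is whether a group of another kind on this carbon, such as an amine, a carboxylic acid or a longer chain, would shift the number in this assay by more than the scatter.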